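Swapping bromo for methyl in compound 2

A few compounds are considered here, and "the series" means these few. Any claim that something is new, unique, unknown or untested is made for them only; others in the source may bear on it.

Measured in a functional assay on thoracic aorta (Rattus norvegicus, strain Wistar), with a stated time of 15 min; on this read-out higher numbers stand for an effect only at larger amounts of compound and lower numbers for an effect already at smaller amounts:
Compound 1 `CC(NC(=O)NS(=O)(=O)c1ccc(Cl)cc1)c1cc(Br)ccc1OCc1ccccc1` gives 57500 nM
Compound 2 `CC(NC(=O)N(C)S(=O)(=O)c1ccc(Cl)cc1)c1cc(Br)ccc1OCc1ccccc1` gives 146000 nM

Of these two numbers, compound 2 has the higher one, so it needs the larger amount to show an effect in this assay. Going by the values given here, the only measured step shows a 2.5-fold higher number from compound 1 to compound 2 (0.40 log units; beyond the scatter), with methyl in place of hydrogen on an amide-type nitrogen. Compound 3 `Cc1ccc(OCc2ccccc2)c(C(C)NC(=O)N(C)S(=O)(=O)c2ccc(Cl)cc2)c1` differs from compound 2 at a single place: methyl in place of bromo on an aromatic carbon. This is methyl in place of bromo on an aromatic carbon, para to a benzyloxy group. Among the compounds with values here, no measured step touches that carbon. Within the data shown here, the one available step concerns a different place, so it offers only a rough sense of how far one small swap can move the number, and it gives no direction for this change. A modest move either way remains possible, but no shift beyond the scatter is expected. The step expected is a 1.0-fold lower number from compound 2 to compound 3 (0.02 log units; within the scatter). The estimated value for compound 3 is 140000 nM, with an expected range from 60000 nM to 320000 nM.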

Compound 3, half-maximal effective concentration: 142000 nM
Compound 3: the middle estimate sits 1.0-fold (0.01 log units) below what was measured; the measured number falls inside the stated range.
By their numbers in this assay, from the lowest: compound 1; then compounds 3 and 2 (each within the scatter of the next).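

In this assay the swap of bromo for methyl on the aromatic carbon para to a benzyloxy group gives a 1.0-fold lower number from compound 2 to compound 3 (0.01 log units; within the scatter) and so leaves the two groups indistinguishable at this position on this read-out. Going by these compounds alone, this is the first look at this carbon: the earlier change at the amide-type nitrogen, a 2.5-fold higher number from compound 1 to compound 2 (0.40 log units; beyond the scatter), moved the number beyond the scatter, whereas this exchange of one heavy atom for one heavy atom, with no hydrogen-bond donors or acceptors and no net charge on either side, does not. No measurement at hand says why bromo and methyl match here.

On these data alone, with only these two groups seen on this carbon, it remains open whether the position is indifferent to what sits there in general, since an amine, a carboxylic acid or a longer chain such as butyl could either shift the number or leave it unchanged. Within the data shown here, it is also open whether the same match would hold with the amide hydrogen of compound 1 in place, as this swap is seen only with methyl on that nitrogen.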